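The source may hold more compounds than are shown below. What is called first, only, known or untested is meant among the compounds shown, and "the series" means these compounds.

Measured so far, both values being limits of a physicochemical assay for lipophilicity, at pH 7.4 (a lower number here means a more polar compound, a higher number a more lipophilic compound), and not numbers:
compound 1 `Cc1cc(CNCCCC[C@@H](Nc2cc(C)c(F)c(C)c2)C(=O)NO)ccc1F` gives < 3 
compound 2 `Cc1ccc(CNCCCC[C@@H](Nc2cc(C)c(F)c(C)c2)C(=O)NO)cc1` gives < 3 

Compound 2 gives < 3 here, a limit and not a number. What the series offers so far is the limit of < 3 in this assay, at which 2 of the 2 values shown sit, and no number to work from.

Compound 3 `COc1ccc(CNCCCC[C@@H](Nc2cc(C)c(F)c(C)c2)C(=O)NO)cc1` has methoxy in place of methyl on an aromatic carbon, para to a large group methoxy in place of methyl on an aromatic carbon and reads as 4-methoxybenzyl where compound 2 has 4-methylbenzyl. Among the measured compounds shown here, the one measured step is a step that the two limits leave unreadable from compound 1 to compound 2 and it puts 4-methylphenyl in place of 4-fluoro-3-methylphenyl, so it is a different change and gives no size to carry over. No direction can be taken from the series either, and no step beyond the scatter is expected in this assay for this change. The expected step is a step that the limit leaves unreadable from compound 2 to compound 3 and this is an estimate only. Compound 3 is expected to read 2.4 with an estimated range from 1.7 to 3 and a report of only a limit would again be unsurprising.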

Compound 3, distribution coefficient: < 3
Compound 3 was reported as a limit (the forecaster's own chance of this, stated with the estimate: 80%); the middle value lies beyond the limit too.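

In this assay compound 3 gives < 3, a limit and not a number. No new step can be read among compound 1, compound 2 and compound 3, which all sit at the same limit: the limit of < 3 in this assay, at which 3 of the 3 values shown sit.

From the compounds shown here alone, whether methoxy in place of methyl on an aromatic carbon changes the distribution coefficient at all, and in which direction, stays open.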